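Swapping the bromine for a trifluoroethoxy group

A few compounds are considered here, and "the series" means these few. Any claim that something is new, unique, unknown or untested is made for them only; others in the source may bear on it.

Measured compounds:
compound 1, `CCc1cccc2c(OC)c(-c3occ(C)c3C(=O)OC)ccc12`: 1.7 ug/mL
compound 2, `CCc1cccc2c(OC)c(-c3occ(C)c3C(=O)NC)ccc12`: > 10 ug/mL
compound 3, `CCc1cccc2c(OC)c(-c3occ(C)c3CBr)ccc12`: > 10 ug/mL

Three compounds sharing one core were tested in a functional assay on KB cells (Homo sapiens) for cytotoxicity, read by MTT assay, with a stated time of 72 h; on this read-out higher numbers stand for an effect only at larger amounts of compound and lower numbers for an effect already at smaller amounts. Compound 1 gives a clear number, 1.7 ug/mL. For compound 2 the assay reports only a limit, > 10 ug/mL. For compound 3 the result is likewise only a limit, > 10 ug/mL, so compound 3 sits at the weak end of what was seen, with the limit of > 10 ug/mL in this assay, at which 2 of the 3 values shown sit.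

Compound 4, `CCc1cccc2c(OC)c(-c3occ(C)c3COCC(F)(F)F)ccc12`, differs from compound 3 by 2,2,2-trifluoroethoxy in place of bromo on a saturated chain carbon bound to an aromatic carbon. The measured steps that touch compound 3 are an at least 5.8-fold higher number from compound 1 to compound 3 (0.76 log units; beyond the scatter) and a step that the two limits leave unreadable from compound 2 to compound 3. Within the data shown here, both changes away from compound 1 led to the limit, and no measured step shows a change on this saturated chain carbon restoring activity. The expected step is therefore small, a step that the limit leaves unreadable from compound 3 to compound 4. Compound 4 is estimated at about 12 ug/mL, within a range from 4 ug/mL to 40 ug/mL, most likely reported again as a limit.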

Compound 4, concentration for half-maximal effect: 6.6 ug/mL
Beside the measured number, compound 4's estimate is 1.8-fold (0.26 log units) above it; measured number inside the range.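

In this assay, compound 3 gives only a limit, > 10 ug/mL. Among these compounds, with 2,2,2-trifluoroethoxy on this saturated chain carbon, compound 4 gives a real number, the first here for a compound without the methoxycarbonyl group, and the result reads as an at least 1.5-fold lower number from compound 3 to compound 4 (0.18 log units; that floor lies within the scatter) and as an at least 1.5-fold lower number from compound 2 to compound 4 (0.18 log units; that floor lies within the scatter). The new group still does not match that ester, with a 3.9-fold higher number from compound 1 to compound 4 (0.59 log units; beyond the scatter), so activity at this position is measurable without the ester but remains lower.

On these data alone, the true size of the gain over the bromo compound stays open, as the starting point has no exact number: the limit of > 10 ug/mL in this assay, at which 2 of the 4 values shown sit. Also open is whether an amine or a carboxylic acid on this saturated chain carbon would bring the number closer to that of compound 1.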